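A few compounds are considered here, and "the series" means these few. Any claim that something is new, unique, unknown or untested is made for them only; others in the source may bear on it.

Working notes on a small set of pyrazoline-type compounds tested in a functional assay on PC-3 cells (Homo sapiens) for cytotoxicity, read by sulforhodamine B assay, with a stated time of 48 h; a lower number here means a stronger inhibitor, a higher number a weaker inhibitor.

Compound 1 `COc1ccc(C2CC(c3ccco3)=NN2C(C)=O)cc1OC` gives 12300 nM in this assay. Compound 2 `COc1cc(OC)c(C2CC(c3ccco3)=NN2C(C)=O)cc1OC` gives 8980 nM in this assay. The two differ in one place, (hydrogen in place of methoxy on an aromatic carbon), and the step of a 1.4-fold higher number from compound 2 to compound 1 (0.14 log units; within the scatter) is small.

Compound 3 `COc1ccc(C2CC(c3ccc4ccccc4c3)=NN2CC=O)c(OC)c1OC` gives 610 nM in this assay, the lowest of the three numbers, beyond the scatter from both compound 2 and compound 1. The difference between the core of compound 3 and the core of compound 2 is not broken down here.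

Compound 4 `COc1ccc(C2CC(c3ccc4ccccc4c3)=NN2CC=O)cc1OC` has not been measured in this assay. It differs from compound 3 by hydrogen in place of methoxy on an aromatic carbon. For the measured compounds named here, this is the same kind of change as the one from compound 2 to compound 1, though the surroundings are not identical: in compound 2 the leaving methoxy sits meta to a methoxy group and para to a methoxy group, whereas in compound 3 it sits ortho to a methoxy group and meta to a methoxy group.

Going by the values given here, the only precedent for this change, a 1.4-fold higher number from compound 2 to compound 1 (0.14 log units; within the scatter), lies within the scatter, so compound 4 is expected to land near compound 3, with an estimated step of a 1.4-fold higher number from compound 3 to compound 4 (0.14 log units; within the scatter) that rests on that one earlier step. Compound 4 is thus estimated at 850 nM in this assay, with a range from 350 nM to 2000 nM allowing for the different surroundings of the change.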

Compound 4, half-maximal inhibitory concentration: 1980 nM
Compound 4: the middle estimate sits 2.3-fold (0.37 log units) below what was measured; low and high end bracket the measured number.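

In this assay, putting hydrogen in place of methoxy on the core of compound 3 gives a 3.2-fold higher number from compound 3 to compound 4 (0.51 log units; beyond the scatter) and so leaves a step that stands clear of the usual variation between repeats on this core. Two pairs are too few to set a general size for this change, and they do not separate the effect of the core from that of the surroundings of the leaving methoxy group, which differ between the pairs; nothing here gives a reason for either step. The comparison shows only that the two steps cannot be told apart, not that they are equal, so the change carries across these two cores only within wide limits: the same change on two cores in this assay, a 1.4-fold higher number (0.14 log units; within the scatter) from compound 2 to compound 1 and a 3.2-fold higher number (0.51 log units; beyond the scatter) from compound 3 to compound 4, 2.4-fold (0.37 log units) apart, within the scatter of two such steps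

The compounds shown leave open whether the result is tied to hydrogen as the entering group, since a hydroxy group, an ethoxy group or a chlorine atom at the same aromatic carbon would test this on both cores. Also open, from the compounds shown here alone, is how the step behaves on a core carrying an amine or a carboxylic acid, and whether the other methoxy groups on the ring of compound 3 can be exchanged in the same way.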